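This account rests on a few compounds, and the source may have more. Where it says the series, first, only, none or still open, it means among the compounds named here.

Compound 1 `N=c1c(C(N)=O)cc(Cl)cn1Cc1ccccc1` is the starting point of this small set. In an assay on CHO-K1 cells for displacement of a labelled ligand from Alpha-1D adrenergic receptor (Homo sapiens), read by scintillation counting, with a stated time of 60 min (a higher number here means a weaker inhibitor, a lower number a stronger inhibitor), compound 1 gives 30 nM. Compound 2 `N=c1c(C(N)=O)cc(Cl)cn1Cc1ccc(Cl)cc1` differs from compound 1 by chloro in place of hydrogen on an aromatic carbon, and in this assay compound 2 gives 23 nM, a step of a 1.3-fold lower number from compound 1 to compound 2 (0.12 log units; within the scatter). Compound 3 `CS(=O)(=O)c1cccc(Cn2cc(Cl)cc(C(N)=O)c2=N)c1` has a different core, which differs from that of compound 1 by methylsulfonyl in place of hydrogen on an aromatic carbon; in this assay compound 3 gives 52 nM, a step of a 1.7-fold higher number from compound 1 to compound 3 (0.24 log units; within the scatter). Compound 4 `CS(=O)(=O)c1cc(Cl)cc(Cn2cc(Cl)cc(C(N)=O)c2=N)c1` has not yet been measured and differs from compound 3 by chloro in place of hydrogen on an aromatic carbon. This is the same kind of change as from compound 1 to compound 2, though not the same: there the place was para to a large group, here it is meta to a large group and meta to a methylsulfonyl group. Because the earlier step of a 1.3-fold lower number from compound 1 to compound 2 (0.12 log units; within the scatter) stayed within the scatter, a similarly small step is expected for compound 4, namely a 1.3-fold lower number from compound 3 to compound 4 (0.11 log units; within the scatter). Compound 4 is therefore estimated at 40 nM, most likely between 20 nM and 80 nM.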

Compound 4, inhibition constant: 4.8 nM
Compound 4: the middle estimate sits 8.3-fold (0.92 log units) above what was measured; the measured number lies below the stated range.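

Chloro in place of hydrogen on an aromatic carbon gives an 11-fold lower number from compound 3 to compound 4 (1.03 log units; beyond the scatter) in this assay. The size of this change therefore did not carry over from one core to the other: the same change on two cores in this assay, a 1.3-fold lower number (0.12 log units; within the scatter) from compound 1 to compound 2 and an 11-fold lower number (1.03 log units; beyond the scatter) from compound 3 to compound 4, 8.3-fold (0.92 log units) apart, beyond the scatter of two such steps. With a single pair on each core, this does not show whether the methylsulfonyl group, the different place of the chloro or both lie behind the gap, and it gives no rule for any other core.

As far as these compounds go, it remains open whether a fluoro, a methoxy or a nitrile in place of this chloro would give a step of similar size. From the compounds shown here alone, it is also open whether chloro would keep such a step if an amine or a carboxylic acid stood in place of the methylsulfonyl group.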